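Swapping the amide substituent on a benzothiazole aniline

A few compounds are considered here, and "the series" means these few. Any claim that something is new, unique, unknown or untested is made for them only; others in the source may bear on it.

Measured compounds:
compound 1 `O=C(Nc1ccc(Cl)cc1)c1cc([N+](=O)[O-])ccc1Cl` — 536 10^-6 cm/s
compound 2 `O=C(O)/C=C/C(=O)Nc1cccc(-c2nc3ccccc3s2)c1` — 4 10^-6 cm/s
compound 3 `O=C(CCl)Nc1cccc(-c2nc3ccccc3s2)c1` — 660 10^-6 cm/s

The read-out throughout is an ADME assay for permeability, using PAMPA; on this read-out lower numbers stand for lower permeability and higher numbers for higher permeability. For the measured compounds named here, compound 3 sits at the top of the three numbers, but compound 1 lies within the scatter of it, so the two cannot be ranked; compound 2 stands far below both, and the only measured step is a 170-fold higher number from compound 2 to compound 3 (2.22 log units; beyond the scatter), in which the 2-carboxyethenyl group on the carbonyl carbon gave way to chloromethyl.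

Compound 4 `O=C(Nc1cccc(-c2nc3ccccc3s2)c1)c1ccnc(Cl)c1` is not yet measured. It differs from compound 3 in one place: 2-chloropyridin-4-yl in place of chloromethyl on a carbonyl carbon. The change sits on the same carbonyl carbon as the measured step, but the group that enters is of a different kind, an aromatic ring rather than a short chain, so that step does not speak directly to it. Going by the values given here, nothing among the measured compounds shows what a ring at this position does in this assay. With that gap, and with compound 1 showing that a different amide arrangement also gives a high number, the expected outcome for compound 4 is a modest move, perhaps downward, of a 1.7-fold lower number from compound 3 to compound 4 (0.22 log units; within the scatter). For compound 4 the estimate in this assay is 400 10^-6 cm/s, with a range from 130 10^-6 cm/s to 900 10^-6 cm/s.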

Compound 4, apparent permeability: 478 10^-6 cm/s
Beside the measured number, compound 4's estimate is 1.2-fold (0.08 log units) below it; low and high end bracket the measured number.
By their numbers in this assay, from the lowest: compound 2; then compounds 4, 1 and 3 (each within the scatter of the next).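

In this assay, a six-membered aromatic ring can stand on this carbonyl carbon in place of a short chain with no readable change, as the step shows: a 1.4-fold lower number from compound 3 to compound 4 (0.14 log units; within the scatter). For the compounds shown here, this is the first sign that the high number at this position is not tied to chloromethyl, since 2-chloropyridin-4-yl, a larger group with a ring nitrogen, gives a number within the scatter of it. Compound 2 now stands apart from two different partners, with a 120-fold higher number from compound 2 to compound 4 (2.08 log units; beyond the scatter) confirming the large gap seen earlier, yet nothing measured here explains that gap or either step.

With one low compound, the results cannot show which part of 2-carboxyethenyl goes with the low number, the carboxylic acid or the chain that carries it. An aromatic ring bearing a carboxylic acid, a longer chain ending in an amine, or a plain pyridine ring without the chlorine on this same carbonyl carbon would each test a question that these four compounds leave open.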